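Little Clearance Shift Expected From an Aryl Swap

The source may report more compounds than this note shows. Statements on the series, on what has been measured and on what is new or still open speak of the compounds shown alone.

Compound 1 `COc1ccc(F)cc1N1C(=O)CSC1c1cccc(C(=O)NCCCCc2ccccc2)c1` gives 2300 mL.min-1.g-1 as its reading in an ADME assay on microsomes from liver (Rattus norvegicus) for metabolic stability, read by LC-MS, using NADPH, with a stated time of 10 min, tested at 0.1 uM (on this read-out higher numbers stand for fast clearance and lower numbers for slow clearance), while compound 2 `O=C(NCCCCc1ccccc1)c1cccc(C2SCC(=O)N2c2cccc(F)c2)c1` gives 3240 mL.min-1.g-1 and compound 3 `O=C(NCCCCc1ccccc1)c1cccc(C2SCC(=O)N2c2ccccc2F)c1` gives 2950 mL.min-1.g-1 on the same scale. Compound 3 stands within the scatter of both others, with a 1.1-fold lower number from compound 2 to compound 3 (0.04 log units; within the scatter) and a 1.3-fold higher number from compound 1 to compound 3 (0.11 log units; within the scatter) as the steps that reach it. Compound 4 `O=C(NCCCCc1ccccc1)c1cccc(C2SCC(=O)N2c2ccc(C3CC3)cc2)c1` has not yet been measured. It carries 4-cyclopropylphenyl in place of 2-fluorophenyl on an amide-type nitrogen in a ring and otherwise keeps the structure of compound 3. Those two steps alter the group on that same nitrogen, as does a 1.4-fold higher number from compound 1 to compound 2 (0.15 log units; within the scatter) with hydrogen in place of methoxy. None of the three brings in a cyclopropyl group, so the measured compounds test this change only indirectly. In this assay compound 3 gives 2950 mL.min-1.g-1. On that basis the estimated step is a 1.1-fold higher number from compound 3 to compound 4 (0.04 log units; within the scatter). Compound 4 is estimated at 3200 mL.min-1.g-1 with 1900 mL.min-1.g-1 to 5400 mL.min-1.g-1 as its expected range.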

Compound 4, intrinsic clearance in microsomes: 2280 mL.min-1.g-1
Compound 4: the middle estimate sits 1.4-fold (0.15 log units) above what was measured; the range from low to high includes it.
By their numbers in this assay, from the lowest: compounds 4, 1, 3 and 2 (each within the scatter of the next).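

In this assay, going by these compounds alone, the amide-type nitrogen in a ring now carries 4-cyclopropylphenyl, the first group here with a three-membered non-aromatic ring of carbon only and with no fluorine, and the reading stays within the scatter of each earlier compound (a 1.3-fold lower number from compound 3 to compound 4 (0.11 log units; within the scatter); a 1.4-fold lower number from compound 2 to compound 4 (0.15 log units; within the scatter); a 1.0-fold lower number from compound 1 to compound 4 (0.00 log units; within the scatter)). At this position, then, the larger carbon-only group and the three smaller aryl groups cannot be told apart on this read-out. Nothing available here accounts for the four readings lying so close together.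

From the compounds shown here alone, it remains open whether any group on this nitrogen would move the reading beyond the scatter, such as a phenyl ring bearing an amine or a carboxylic acid. Changes elsewhere on the shared core, including a longer chain, are equally open.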